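Working notes on the aryl swap from compound 1 to compound 3

A few compounds are considered here, and "the series" means these few. Any claim that something is new, unique, unknown or untested is made for them only; others in the source may bear on it.

Measured so far:
- Compound 1 `N#CC1=C(N)OC(c2c[nH]c3ccccc23)=C(C#N)C1c1ccccc1Cl`: in a functional assay (a higher number here means a weaker inhibitor, a lower number a stronger inhibitor), compound 1 gives > 1000 ug/mL, which is a limit of the assay and not a number.
- Compound 2 `Cc1ccc(C2C(C#N)=C(N)OC(c3c[nH]c4ccccc34)=C2C#N)cc1`: in this assay compound 2 gives > 1000 ug/mL, likewise a limit.

Within the data shown here, compound 1 therefore stands only at a limit in this assay, and the one further value shown is a limit too; both sit at the limit of > 1000 ug/mL in this assay, at which 2 of the 2 values shown sit. Among the measured compounds shown here, the single measured step on the saturated ring carbon, a step that the two limits leave unreadable from compound 1 to compound 2, is left unreadable by the two limits, so its size and direction are unknown.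

Compound 3 `COc1ccc(C2C(C#N)=C(N)OC(c3c[nH]c4ccccc34)=C2C#N)cc1` is not yet measured. It differs from compound 1 in one place: 4-methoxyphenyl in place of 2-chlorophenyl on a saturated ring carbon. For the measured compounds named here, the only measured step that bears on this change is the one from compound 1 to compound 2, and it is unreadable, so no direction can be drawn from it and no step beyond the scatter is expected in either sense.

Compound 3 is thus expected to sit around 1200 ug/mL, with a range of 400 ug/mL to 3000 ug/mL, most probably again reported only as a limit. The expected step from compound 1 is a step that the limit leaves unreadable from compound 1 to compound 3.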

Compound 3, half-maximal inhibitory concentration: 859 ug/mL
The estimate for compound 3 lay 1.4-fold (0.15 log units) above the measured number, within the range that was stated.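

Among these compounds, compound 3 holds the only value shown in this assay that is a number and not a limit: with 4-methoxyphenyl on the saturated ring carbon, compound 3 gives 859 ug/mL. Against the 2-chlorophenyl group the change gives an at least 1.1-fold lower number from compound 1 to compound 3 (0.06 log units; that floor lies within the scatter), and methoxy in place of methyl on the aromatic carbon gives an at least 1.1-fold lower number from compound 2 to compound 3 (0.06 log units; that floor lies within the scatter); as both floors lie within the scatter, neither change is yet shown to give a real gain, though the true steps may be larger. Those true sizes stay unknown because compound 1 and compound 2 are held only by limits: the limit of > 1000 ug/mL in this assay, at which 2 of the 3 values shown sit.

The step between compound 1 and compound 2 cannot be read, so the effect of the methyl group and that of the chlorine on the phenyl ring stay unresolved against each other, and a single number gives no trend on this ring carbon. Also open, as far as these compounds go, is whether a hydroxy group, a dimethylamino group or a longer chain such as ethoxy in place of the methoxy would move the number beyond the scatter from compound 3.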